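Swapping the pyrazole for a thiophene on the acetyl chain

This account rests on a few compounds, and the source may have more. Where it says the series, first, only, none or still open, it means among the compounds named here.

Compound 1, `Cc1ccccc1N/C(=N\C#N)N1CCN(C(=O)Cc2ccsc2)C(c2ccccc2)C1`: 270 nM
Compound 2, `Cc1ccccc1N/C(=N\C#N)N1CCN(C(=O)Cn2nccc2C)C(c2ccccc2)C1`: 560 nM

Going by the values given here, in a functional assay for antagonist activity at P2X purinoceptor 7 (Rattus norvegicus), read by FLIPR and calcium flux (on this read-out higher numbers stand for weaker inhibition and lower numbers for stronger inhibition), compound 2 holds the higher of the two numbers; the only measured step is a 2.1-fold higher number from compound 1 to compound 2 (0.32 log units; beyond the scatter). Compound 3, `Cc1ccccc1N/C(=N\C#N)N1CCN(C(=O)Cc2cccs2)C(c2ccccc2)C1`, differs from compound 2 in that (thiophen-2-yl in place of 5-methyl-1H-pyrazol-1-yl on a saturated chain carbon bound to a carbonyl carbon). This largely reverses that earlier step, although the entering ring is a thiophen-2-yl rather than the thiophen-3-yl of compound 1, so a modest step downward in this assay is expected, about a 1.9-fold lower number from compound 2 to compound 3 (0.27 log units; within the scatter). Compound 3 is therefore estimated at 300 nM, with a likely range from 150 nM to 600 nM.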

Compound 3, half-maximal inhibitory concentration: 150 nM
The estimate for compound 3 lay 2.0-fold (0.30 log units) above the measured number; the measured number falls inside the stated range.
By their numbers in this assay, from the lowest: compounds 3 and 1 (each within the scatter of the next); then compound 2.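

In this assay, the advantage over 5-methyl-1H-pyrazol-1-yl extends to a second thiophene, with a 3.7-fold lower number from compound 2 to compound 3 (0.57 log units; beyond the scatter), so it is not confined to thiophen-3-yl. On this saturated chain carbon bound to a carbonyl carbon, thiophen-2-yl and thiophen-3-yl cannot be told apart, with a 1.8-fold lower number from compound 1 to compound 3 (0.26 log units; within the scatter). Nothing available explains the gap between the thiophenes and the pyrazole.

The compounds shown leave open whether the methyl group or the pyrazole ring itself accounts for that gap, which an unsubstituted pyrazol-1-yl would address. On these data alone, how a phenyl ring or an amine would fare on the same chain carbon also remains open.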